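Removing tert-butoxycarbonyl from compound 3

The compounds below may be only part of what the source reports. "The series", "measured", "known", "first", "only" and "open" are said of these compounds alone.

In a functional assay (Mus musculus) for cytotoxicity (on this read-out lower numbers stand for higher toxicity in this test and higher numbers for lower toxicity in this test), compound 1 (`COC(=O)c1ccc([N+](=O)[O-])o1`) gives 32000 nM and compound 2 (`O=C(Cc1ccccc1)NNC(=O)c1ccc([N+](=O)[O-])o1`) gives 32000 nM on the same read-out. Compound 3 (`CC(C)(C)OC(=O)N[C@@H](C(=O)NNC(=O)c1ccc([N+](=O)[O-])o1)c1ccccc1`) gives 32000 nM and so stands level with both. Compound 4 (`N[C@@H](C(=O)NNC(=O)c1ccc([N+](=O)[O-])o1)c1ccccc1`) has hydrogen in place of tert-butoxycarbonyl on an amine nitrogen and thus carries amino where compound 3 carries (tert-butoxycarbonyl)amino. Going by the values given here, one measured step bears on this: no change at the digits printed from compound 2 to compound 3 (within the scatter) came with (tert-butoxycarbonyl)amino in place of hydrogen on a saturated chain carbon bound to an aromatic carbon and a carbonyl carbon, and it stays within the scatter. That step does not isolate the present change. Among the compounds with values here, no measured compound carries the free amino, so the range is left wider toward lower numbers. The step expected is a 1.3-fold lower number from compound 3 to compound 4 (0.11 log units; within the scatter) in this assay and no larger than the scatter, leaning if at all toward lower numbers. For compound 4 the estimated value is 25000 nM in this assay (expected range 8000 nM to 40000 nM).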

Compound 4, half-maximal cytotoxic concentration: 32000 nM
Beside the measured number, compound 4's estimate is 1.3-fold (0.11 log units) below it; the measured number falls inside the stated range.
By their numbers in this assay, from the lowest: compounds 1, 2, 3 and 4 (each within the scatter of the next).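

In this assay, taking tert-butoxycarbonyl off the amine nitrogen gives no change at the digits printed from compound 3 to compound 4 (within the scatter), so the free amino group and (tert-butoxycarbonyl)amino cannot be told apart on this read-out. Placing amino in place of hydrogen on the saturated chain carbon gives no change at the digits printed from compound 2 to compound 4 (within the scatter), and together with no change at the digits printed from compound 2 to compound 3 (within the scatter) this means that hydrogen, amino and (tert-butoxycarbonyl)amino at this carbon all sit within the scatter of one another. Nothing available explains this flat result.

Going by these compounds, whether a carboxylic acid or a longer chain on this saturated chain carbon would shift the number in this assay remains open. Also open, on these data alone, is whether a dimethylamino group in place of amino, or the opposite configuration at this carbon, would separate from compound 4 .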